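The source may hold more compounds than are shown below. What is called first, only, known or untested is meant among the compounds shown, and "the series" means these compounds.

Measured so far in a functional assay on DLD-1 cells (Homo sapiens) for antiproliferative activity, read by CellTiter-Glo, with a stated time of 72 h; a higher number here means a weaker inhibitor, a lower number a stronger inhibitor:
compound 1 `Cc1noc(C)c1S(=O)(=O)N1CCC(N2CCC(C)CC2)CC1` gives > 5000 nM, a limit of the assay.
compound 2 `Cc1ccc(-c2ccccc2S(=O)(=O)N2CCC(N3CCC(C)CC3)CC2)cc1` gives 366 nM.
compound 3 `CC1CCN(C2CCN(S(=O)(=O)c3cccnc3Cl)CC2)CC1` gives > 5000 nM, a limit of the assay.

Within the data shown here, compound 3 stands at the limit, the place where two of the three values so far sit (the limit of > 5000 nM in this assay, at which 2 of the 3 values shown sit). Among the measured compounds shown here, the only step that touches it, a step that the two limits leave unreadable from compound 1 to compound 3, has limits at both ends and stays unreadable in size. For the measured compounds named here, compound 2 is the single member of the series with a number rather than a limit.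

Compound 4 `CC1CCN(C2CCN(S(=O)(=O)c3ccc(C#N)cc3)CC2)CC1` is not yet measured. It differs from compound 3 by 4-cyanophenyl in place of 2-chloropyridin-3-yl on a sulfonyl sulfur. Going by the values given here, no measured step bears directly on this exchange; the one step into compound 3 is unreadable, and compound 2 carries a different aryl group with no step to either. The expectation therefore rests on the weight of limits in the series. Compound 4 is expected to stay weak in this assay, with a real chance of another limit. Compound 4 is estimated at 3500 nM, in the range 1000 nM to 12000 nM. The expected step of an at least 1.4-fold lower number from compound 3 to compound 4 (0.15 log units; that floor lies within the scatter) is thus small or none beyond the scatter.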

Compound 4, half-maximal inhibitory concentration: 2800 nM
For compound 4 the middle estimate is 1.3-fold (0.10 log units) above the measured one; low and high end bracket the measured number.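

With 4-cyanophenyl on the sulfonyl sulfur, the series gains a second number rather than a limit, and the exchange gives an at least 1.7-fold lower number from compound 3 to compound 4 (0.25 log units; that floor lies within the scatter) and an at least 1.7-fold lower number from compound 1 to compound 4 (0.25 log units; that floor lies within the scatter) in this assay for this position. Compound 2 gives 366 nM and compound 4 gives 2800 nM with only the group on that sulfur differing, so the printed values now spread across two measured numbers at this place. Compound 1 and compound 3 remain limits, so both steps are floors whose true size stays unread: the limit of > 5000 nM in this assay, at which 2 of the 4 values shown sit.

Open, going by these compounds, is whether the nitrile or the carbon-only ring carries the step; a plain phenyl, a carboxylic acid or an amine in place of the nitrile would separate the two. Also open, on these data alone, is how the shared core, unchanged throughout, contributes to these values.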